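Replacing 2,4,6-trimethylphenyl with 4-methoxyphenyl in compound 3

This account rests on a few compounds, and the source may have more. Where it says the series, first, only, none or still open, it means among the compounds named here.

In a functional assay on K562 cells (Homo sapiens) for cytotoxicity, read by MTT assay, with a stated time of 48 h (a lower number here means a stronger inhibitor, a higher number a weaker inhibitor), compound 1 `Cc1ccc(CN2CCN(C(=O)CN[C@H]3CCN(S(=O)(=O)Cc4ccccc4)C3)CC2)cc1` gives 8200 nM and compound 2 `O=C(CN[C@H]1CCN(S(=O)(=O)Cc2ccccc2)C1)N1CCN(Cc2ccc(Cl)cc2)CC1` gives 9200 nM as its number. Chloro in place of methyl amounts to a 1.1-fold higher number from compound 1 to compound 2 (0.05 log units; within the scatter) in this pair. Compound 3 `Cc1cc(C)c(CN2CCN(C(=O)CN[C@H]3CCN(S(=O)(=O)Cc4ccccc4)C3)CC2)c(C)c1` at 3300 nM holds the lowest of the three numbers, and both of the others lie beyond the scatter from it.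

Compound 4 `COc1ccc(CN2CCN(C(=O)CN[C@H]3CCN(S(=O)(=O)Cc4ccccc4)C3)CC2)cc1` is still unmeasured. It carries 4-methoxyphenyl in place of 2,4,6-trimethylphenyl on a saturated chain carbon bound to an amine nitrogen in a ring. Among the compounds with values here, no compound with a methoxy group has been measured, so the evidence is indirect. Since a 2.5-fold lower number from compound 1 to compound 3 (0.40 log units; beyond the scatter) and a 2.8-fold lower number from compound 2 to compound 3 (0.45 log units; beyond the scatter) are both modest drops on reaching 2,4,6-trimethylphenyl, a modest rise is expected on leaving it, back towards the level shared by the 4-methylphenyl and 4-chlorophenyl compounds. The expected step is a 2.4-fold higher number from compound 3 to compound 4 (0.38 log units; beyond the scatter) and would lie beyond the scatter. For compound 4 the estimated value is 8000 nM with an expected range from 4000 nM to 16000 nM in this assay.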

Compound 4, half-maximal inhibitory concentration: 50900 nM
The estimate for compound 4 lay 6.4-fold (0.80 log units) below the measured number, outside the stated range (above it).
By their numbers in this assay, from the lowest: compound 3; then compounds 1 and 2 (each within the scatter of the next); then compound 4.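

In this assay, within the data shown here, the change to 4-methoxyphenyl (a 15-fold higher number from compound 3 to compound 4 (1.19 log units; beyond the scatter)) is a large step, so this position can move the number much further than the earlier compounds showed. Compounds 1 and 2 had suggested that the group on this aromatic carbon made little difference, as methyl and chloro stood within the scatter of each other, but methoxy breaks from both (a 6.2-fold higher number from compound 1 to compound 4 (0.79 log units; beyond the scatter); a 5.5-fold higher number from compound 2 to compound 4 (0.74 log units; beyond the scatter)). Compound 4 therefore has the highest number of the four, beyond the scatter from each of the others.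

Nothing shown here accounts for this rise. Going by these compounds, it remains open whether the rise is specific to methoxy or would extend to an ethoxy or hydroxy group on the same aromatic carbon.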